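A few compounds are considered here, and "the series" means these few. Any claim that something is new, unique, unknown or untested is made for them only; others in the source may bear on it.

Compound 1 `CC(C)CN1C(=O)CN(Cc2ccc(-c3ccc(F)c(CN4CCCCC4)n3)cc2)C1=O`: 0.217 h
Compound 2 `CCN1C(=O)CN(Cc2ccc(-c3ccc(F)c(CN4CCCCC4)n3)cc2)C1=O`: 1.45 h

Both values come from an in vitro ADME assay on microsomes from liver (Homo sapiens) for metabolic stability, read by LC-MS, using NADPH, tested at 1 uM (on this read-out higher numbers stand for a longer-lived compound and lower numbers for a shorter-lived compound), and compound 2 holds the higher of the two numbers. The next structure, compound 3 `O=C1CN(Cc2ccc(-c3ccc(F)c(CN4CCCCC4)n3)cc2)C(=O)N1CC1CCC1`, departs from compound 2 by cyclobutyl in place of methyl on a saturated chain carbon bound to an amide-type nitrogen in a ring. Cut one bond further out, the same difference reads ethyl to cyclobutylmethyl.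

Among the compounds with values here, only one measured step bears on this place: a 6.7-fold higher number from compound 1 to compound 2 (0.82 log units; beyond the scatter), with methyl in place of isopropyl. The new change runs the opposite way, from methyl to a group of more carbons. Cyclobutyl itself has not been measured here, so the comparison with isopropyl is only a guide. Going by compound 1 at 0.217 h, a lower number of similar size is expected in this assay, beyond the scatter. The expected step is a 4.8-fold lower number from compound 2 to compound 3 (0.68 log units; beyond the scatter). For compound 3 the estimated half-life is 0.3 h, with an expected range of 0.1 h to 0.8 h.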

Compound 3, half-life: 0.0833 h
For compound 3 the middle estimate is 3.6-fold (0.56 log units) above the measured one, outside the stated range (below it).
By their numbers in this assay, from the lowest: compound 3; then compound 1; then compound 2.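

In this assay, the step to cyclobutyl is a 17-fold lower number from compound 2 to compound 3 (1.24 log units; beyond the scatter), so a group with a ring at this place on a saturated chain carbon bound to an amide-type nitrogen in a ring can cost more than the earlier isopropyl comparison suggested. Isopropyl and cyclobutyl are also not interchangeable here: replacing isopropyl with cyclobutyl gives a 2.6-fold lower number from compound 1 to compound 3 (0.42 log units; beyond the scatter), which places both groups below methyl, with cyclobutyl lowest among the three compounds. Nothing measured here accounts for these differences in half-life.

Within the data shown here, the three compounds leave open whether the fall follows the number of carbons in the group or the presence of the ring itself, since only one ring-bearing group stands at this place. A cyclopropyl group would help to separate those two readings, while a hydrogen in place of methyl, or a chain carrying a hydroxyl group or an ether oxygen, would show whether the half-life can rise further or how it responds when the group is no longer carbon only.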